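A few compounds are considered here, and "the series" means these few. Any claim that something is new, unique, unknown or untested is made for them only; others in the source may bear on it.

Measured in a functional assay on the whole organism for inhibition, with Mus musculus as the target; on this read-out lower numbers stand for an effect already at smaller amounts and higher numbers for an effect only at larger amounts of compound:
- compound 1 `CCCNC(=O)Nc1cccc2c1CN(C)CC2c1ccccc1`: > 80 mg/kg (a limit of the assay)
- compound 2 `CCCCOC(=O)Nc1cccc2c1CN(C)CC2c1ccccc1`: 2.6 mg/kg

Going by the values given here, compound 2 holds the only actual number so far. Compound 3 `CC(C)NCCC(=O)Nc1cccc2c1CN(C)CC2c1ccccc1` has 2-(isopropylamino)ethyl in place of butoxy on a carbonyl carbon. Among the compounds with values here, the one measured step at this place is large: an at least 30-fold lower number from compound 1 to compound 2 (1.48 log units; beyond the scatter). Within the data shown here, with only that step to go on, a sizeable move toward a higher number is expected in this assay. The expected step is a 7.7-fold higher number from compound 2 to compound 3 (0.89 log units; beyond the scatter). Compound 3 is estimated at 20 mg/kg, with an expected range of 4 mg/kg to 80 mg/kg.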

Compound 3, dose for half-maximal effect: about 125 mg/kg
Compound 3: middle estimate off by 6.3-fold (0.80 log units), on the low side, outside the stated range (above it).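

In this assay, 2-(isopropylamino)ethyl in place of butoxy on a carbonyl carbon gives a 48-fold higher number from compound 2 to compound 3 (1.68 log units; beyond the scatter), so a second group now goes with a far higher number than butoxy. Among the compounds shown, only butoxy gives a low number at this position. Compound 1 carries a limit, not a number, so its step to compound 3 cannot be read: the limit of > 80 mg/kg in this assay, at which 1 of the 3 values shown sits.

Still open, going by these compounds, is whether the oxygen of butoxy or the chain itself carries the difference. A pentyl or a propoxy group on the same carbonyl carbon would separate the two.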